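Cyclopentyl for Propyl on the Shared Core

This account rests on a few compounds, and the source may have more. Where it says the series, first, only, none or still open, it means among the compounds named here.

Going by the values given here, compound 3 `CCCNc1nnc2nncn2n1` gives 15100 nM in a functional assay on HL-60 cells (Homo sapiens) for inhibition, read by MTT assay, with a stated time of 72 h (a lower number here means a stronger inhibitor, a higher number a weaker inhibitor), the lowest of the three numbers measured so far. Compound 1 `OCCNc1nnc2nncn2n1` gives 45300 nM and compound 2 `CC(Nc1nnc2nncn2n1)C(=O)O` gives 74300 nM, so compound 3 stands apart from both by more than the usual scatter.

Compound 4 `c1nnc2nnc(NC3CCCC3)nn12` keeps the core of compound 3 and changes one thing: cyclopentyl in place of propyl on a nitrogen on an aromatic ring.

Among the compounds with values here, two measured steps bear on this change, though only loosely. The step of a 3.0-fold lower number from compound 1 to compound 3 (0.48 log units; beyond the scatter) and the step of a 4.9-fold lower number from compound 2 to compound 3 (0.69 log units; beyond the scatter) both ended at compound 3, each swapping a group on the same nitrogen for a plain hydrocarbon piece and each lowering the number modestly. Within the data shown here, no measured pair, however, compares one hydrocarbon group with another, so the effect of trading the propyl chain for a five-membered ring is not covered by the data. The safest expectation is therefore a step from compound 3 to compound 4 of about a 1.5-fold lower number from compound 3 to compound 4 (0.18 log units; within the scatter), that is, a small shift toward a lower number, not clearly beyond the scatter.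

On that basis compound 4 is estimated at 10000 nM in this assay, with a plausible range from 3000 nM to 35000 nM.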

Compound 4, half-maximal inhibitory concentration: 38200 nM
The estimate for compound 4 lay 3.8-fold (0.58 log units) below the measured number; the whole stated range lies below it.
By their numbers in this assay, from the lowest: compound 3; then compounds 4, 1 and 2 (each within the scatter of the next).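

In this assay, going by these compounds alone, this is the first comparison of one hydrocarbon group with another on this nitrogen, and the change matters: there is a 2.5-fold higher number from compound 3 to compound 4 (0.40 log units; beyond the scatter) when the ring replaces the chain. The earlier steps shown here to compound 3 might have suggested that a plain hydrocarbon group on this nitrogen is enough for a lower number, but compound 4 goes against that reading, as its number cannot be separated from those of the two compounds with oxygen-bearing groups (a 1.9-fold lower number from compound 2 to compound 4 (0.29 log units; within the scatter) and a 1.2-fold lower number from compound 1 to compound 4 (0.07 log units; within the scatter), both within the scatter). Propyl therefore remains the only group here that stands clearly apart from the others, and no measurement is available to explain the difference between the chain and the ring.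

From the compounds shown here alone, it remains open whether the higher number follows from the ring itself or from the larger group, and a pentyl chain or a smaller cyclopropyl ring on the same nitrogen would help separate the two. The compounds shown also leave open how a butyl chain, a branched isopropyl group or an aromatic phenyl ring would behave at this position.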